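A few compounds are considered here, and "the series" means these few. Any claim that something is new, unique, unknown or untested is made for them only; others in the source may bear on it.

Measured compounds:
- compound 1, `COCN(c1ccc2c(c1)S(=O)(=O)N=C(c1c(O)c(-c3cccs3)nn(CCC(C)C)c1=O)N2)S(C)(=O)=O`: 0.183 h
- compound 2, `CC(C)CCn1nc(-c2ccccc2)c(O)c(C2=NS(=O)(=O)c3cc(NS(C)(=O)=O)ccc3N2)c1=O`: 0.633 h
- compound 3, `CC(C)(C)CCn1nc(-c2cccs2)c(O)c(C2=NS(=O)(=O)c3cc(NS(C)(=O)=O)ccc3N2)c1=O`: > 1 h

In an in vitro ADME assay on microsomes from liver (Homo sapiens) for metabolic stability, tested at 5 uM (on this read-out lower numbers stand for a shorter-lived compound and higher numbers for a longer-lived compound), compound 1 gives 0.183 h and compound 2 gives 0.633 h. For compound 3 the result is a limit of the assay rather than a number, > 1 h, so compound 3 sits at the limit of > 1 h in this assay, at which 1 of the 3 values shown sits, and its exact position is not known. The unmeasured compound 4, `CS(=O)(=O)Nc1ccc2c(c1)S(=O)(=O)N=C(c1c(O)c(-c3cccs3)nn(CC3(C(F)(F)F)CCC3)c1=O)N2`, differs from compound 3 in one place: 1-(trifluoromethyl)cyclobutyl in place of neopentyl on a saturated chain carbon bound to an aromatic nitrogen. Going by the values given here, no measured pair isolates this change, so the account cannot say which direction it pushes the half-life. The step from compound 3 to compound 4 is expected to be a number no higher from compound 3 to compound 4 (the limit leaves the size open), within the usual scatter. In this assay compound 4 is therefore expected to give about 1 h, with a range from 0.4 h to 2.5 h.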

Compound 4, half-life: 1 h
Estimate against measurement, compound 4: no gap at the digits printed; measured number inside the range.
By their numbers in this assay, from the lowest: compound 1; then compounds 2 and 4 (each within the scatter of the next).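

Going by these compounds alone, at this place, on a saturated chain carbon bound to an aromatic nitrogen, compound 4 gives 1 h in this assay with 1-(trifluoromethyl)cyclobutyl, the first group here with a ring and fluorine. The change reads a number no higher from compound 3 to compound 4 (the limit leaves the size open) and its size cannot be read. Compound 3 stands at a limit of the assay and not at a number: the limit of > 1 h in this assay, at which 1 of the 4 values shown sits.

The compounds shown leave open how the ring and the trifluoromethyl each count alone, which a plain cyclobutyl in the same place would separate. From the compounds shown here alone, how an amine on that chain would read also stays open.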